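The source may report more compounds than this note shows. Statements on the series, on what has been measured and on what is new or still open speak of the compounds shown alone.

Compound 1, `O=S(=O)(/C=C/c1ccc(Br)cc1)Cc1ccc(Nc2ncnc3ccccc23)cc1`: in a functional assay on U-251 cells (Homo sapiens) (a lower number here means a stronger inhibitor of growth, a higher number a weaker inhibitor of growth), compound 1 gives > 100000 nM, which is a limit of the assay and not a number.
Compound 2, `O=S(=O)(/C=C/c1ccc(Cl)cc1)Cc1ccc(Nc2ncnc3ccccc23)cc1`: in this assay compound 2 gives 49000 nM.
Compound 3, `O=S(=O)(/C=C/c1ccc(Br)cc1)Cc1ccc(Nc2ncnc3ccc(Br)cc23)cc1`: in this assay compound 3 gives 11000 nM.

Two changes link these three compounds. The first, (chloro in place of bromo on an aromatic carbon), gave an at least 2.0-fold lower number from compound 1 to compound 2 (0.30 log units; that floor lies within the scatter). The second, (bromo in place of hydrogen on an aromatic carbon), gave an at least 9.0-fold lower number from compound 1 to compound 3 (0.95 log units; beyond the scatter); this is also how the core of compound 3 differs from the core of compound 1. Compound 3 thus gives the lowest of the two numbers measured.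

Compound 4, `O=S(=O)(/C=C/c1ccc(Cl)cc1)Cc1ccc(Nc2ncnc3ccc(Br)cc23)cc1`, has not yet been measured. It differs from compound 3 by chloro in place of bromo on an aromatic carbon, the same change that was made from compound 1 to compound 2, at the same place. The expected step in this assay from compound 3 to compound 4 is a 1.8-fold lower number from compound 3 to compound 4 (0.26 log units; within the scatter), set beside the earlier at least 2.0-fold lower number from compound 1 to compound 2 (0.30 log units; that floor lies within the scatter), whose floor lies within the scatter, so the expectation is loose. Compound 4 is expected to give about 6000 nM, within a range from 2000 nM to 20000 nM.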

Compound 4, concentration for 50% growth inhibition: 30000 nM
For compound 4 the middle estimate is 5.0-fold (0.70 log units) below the measured one; the whole stated range lies below it.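

On the core of compound 3, 4-chlorophenyl in place of 4-bromophenyl gave a 2.7-fold higher number from compound 3 to compound 4 (0.44 log units; beyond the scatter), so in this assay this change did not carry over unchanged from the core of compound 1: the same change on two cores in this assay, an at least 2.0-fold lower number (0.30 log units; that floor lies within the scatter) from compound 1 to compound 2 and a 2.7-fold higher number (0.44 log units; beyond the scatter) from compound 3 to compound 4, at least 5.5-fold (0.74 log units) apart, beyond the scatter of two such steps

Bromo in place of hydrogen on the core, read with the 4-chlorophenyl group in place, gave a 1.6-fold lower number from compound 2 to compound 4 (0.21 log units; within the scatter), and this step also differs from its counterpart: the same change on two cores in this assay, an at least 9.0-fold lower number (0.95 log units; beyond the scatter) from compound 1 to compound 3 and a 1.6-fold lower number (0.21 log units; within the scatter) from compound 2 to compound 4, at least 5.5-fold (0.74 log units) apart, beyond the scatter of two such steps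

Both earlier steps start from compound 1, whose > 100000 nM is a limit of the assay and not a number; the four compounds therefore show that each change depends on the other group present, but not by how much the steps truly differ, nor why.

Still open, as far as these compounds go, is whether the same dependence would appear with a fluoro or methoxy group in place of the halogen on the phenyl ring. From the compounds shown here alone, it is equally open how an amine in place of the bromo on the core of compound 3 would behave in this assay.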